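The source may report more compounds than this note shows. Statements on the series, on what has been measured and on what is new or still open speak of the compounds shown alone.

In a functional assay (muscle tissue) with Rattus norvegicus as the target (on this read-out lower numbers stand for an effect already at smaller amounts and higher numbers for an effect only at larger amounts of compound), compound 1 `CCNC(=O)C1=CC(C)(C)Oc2ccc([N+](=O)[O-])cc21` gives 4.57 nM and compound 2 `CC1(C)C=C(C(=O)NCC2CC2)c2cc([N+](=O)[O-])ccc2O1` gives 6.61 nM, so these two stand within the scatter of each other. The next compound to be measured is compound 3 `CC1(C)C=C(C(=O)NCCO)c2cc([N+](=O)[O-])ccc2O1`, with the change (hydroxymethyl in place of cyclopropyl on a saturated chain carbon bound to an amide-type nitrogen). Within the data shown here, the only measured step at this place is a 1.4-fold higher number from compound 1 to compound 2 (0.16 log units; within the scatter). That step involved no hydroxymethyl group, so it offers only loose guidance, and a modest move towards a higher number is expected. The step expected in this assay is a 2.1-fold higher number from compound 2 to compound 3 (0.33 log units; beyond the scatter). Compound 3 is estimated at 14 nM, with an expected range of 4 nM to 50 nM.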

Compound 3, half-maximal effective concentration: 182 nM
Compound 3: middle estimate off by 13-fold (1.11 log units), on the low side, outside the stated range (above it).
By their numbers in this assay, from the lowest: compounds 1 and 2 (each within the scatter of the next); then compound 3.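

In this assay this position is not indifferent to change: 2-hydroxyethyl in place of cyclopropylmethyl gives a 28-fold higher number from compound 2 to compound 3 (1.44 log units; beyond the scatter), whereas the earlier step here stayed within the scatter. Hydroxy in place of hydrogen on the saturated chain carbon alone gives a 40-fold higher number from compound 1 to compound 3 (1.60 log units; beyond the scatter), so among these compounds the large rise goes with the hydroxy group and not with the loss of the cyclopropyl ring. No available data bear on the cause of this rise. Going by these compounds, whether a methoxy group, an amine or a carboxylic acid at the chain end behaves like the hydroxy group remains open. So does the outcome for a longer chain without oxygen.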